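A few compounds are considered here, and "the series" means these few. Any claim that something is new, unique, unknown or untested is made for them only; others in the source may bear on it.

Working notes on the series. In a functional assay (Sus scrofa) with sulfonylurea receptors; K-ATP channels (Homo sapiens) as the target (on this read-out lower numbers stand for an effect already at smaller amounts and higher numbers for an effect only at larger amounts of compound), compound 1, `CCCC(=O)Nc1c(C(O)(C(F)(F)F)C(F)(F)F)ccc2ccccc12`, gives 708 nM and compound 2, `C/C=C/C(=O)Nc1c(C(O)(C(F)(F)F)C(F)(F)F)ccc2ccccc12`, gives 49 nM. Compound 2 holds the lowest of the two numbers; its nearest neighbour on this read-out is compound 1, reached by a 14-fold lower number from compound 1 to compound 2 (1.16 log units; beyond the scatter). Compound 3, `O=C(Nc1c(C(O)(C(F)(F)F)C(F)(F)F)ccc2ccccc12)C1CC1`, is not yet measured. It differs from compound 2 by cyclopropyl in place of prop-1-en-1-yl on a carbonyl carbon. Among the compounds with values here, no measured step exchanges an alkene for a ring; the only step at this carbonyl carbon is a 14-fold lower number from compound 1 to compound 2 (1.16 log units; beyond the scatter), which shows that an open propyl chain and its unsaturated counterpart sit far apart. Cyclopropyl is neither of these, so the expectation rests on weak ground, and a number between compound 1 and compound 2 is expected, with the chance of a rise rather than a fall. Compound 3 is therefore estimated at 130 nM, range 40 nM to 450 nM, corresponding to an expected 2.7-fold higher number from compound 2 to compound 3 (0.42 log units; beyond the scatter).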

Compound 3, half-maximal effective concentration: 126 nM
For compound 3 the middle estimate is 1.0-fold (0.01 log units) above the measured one; low and high end bracket the measured number.
By their numbers in this assay, from the lowest: compound 2; then compound 3; then compound 1.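

In this assay, a 5.6-fold lower number from compound 1 to compound 3 (0.75 log units; beyond the scatter), so a low number at this carbonyl carbon does not require a double bond outside aromatic rings: cyclopropyl, which has none, also stands well clear of propyl. Even so, a 2.6-fold higher number from compound 2 to compound 3 (0.41 log units; beyond the scatter), so two groups of 3 carbon atoms are not interchangeable here, and prop-1-en-1-yl keeps the lowest number of the three compounds. No supporting data bear on the reason for this order.

Still open, on these data alone, is how a longer chain such as butyl, a larger ring such as cyclobutyl, or an amine on the same carbonyl carbon would read out. Also open, as far as these compounds go, is whether the order of these three groups would hold if another part of the shared core were changed.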